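Shortened thioether chain: from compound 2 to compound 4

The source may hold more compounds than are shown below. What is called first, only, known or untested is meant among the compounds shown, and "the series" means these compounds.

Of the compounds shown here, three have been measured in an assay on isolated protein for inhibition of deoxycytidine kinase (Rattus norvegicus); on this read-out higher numbers stand for weaker inhibition and lower numbers for stronger inhibition. Compound 1 `CCCCCCCCOc1nccc(N)n1` gives 1000000 nM. Compound 2 `Nc1ccnc(SCCCCc2ccccc2)n1` gives 1000000 nM, level with compound 1 at the digits shown, the two together the lowest of the three numbers, although the gap to compound 3 lies within the scatter. Compound 3 `Nc1ccn(-c2cccc3ccccc23)c(=O)n1` gives 1500000 nM. No pair among these three differs in a single place, so no step between measured compounds can be read.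

Compound 4 `CCCCCSc1nccc(N)n1` is not yet measured. It differs from compound 2 as follows: methyl in place of phenyl on a saturated chain carbon, four bonds along the chain from a sulfur. Since compound 1 gives 1000000 nM and compound 2 gives 1000000 nM, no change beyond the scatter is expected in either direction. Compound 4 is estimated at 1000000 nM, within 300000 nM to 3000000 nM. This estimate means an expected step of no change at the digits printed from compound 2 to compound 4 (within the scatter).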

Compound 4, half-maximal inhibitory concentration: 2600000 nM
Compound 4: middle estimate off by 2.6-fold (0.41 log units), on the low side; the range from low to high includes it.
By their numbers in this assay, from the lowest: compounds 1, 2, 3 and 4 (each within the scatter of the next, the first and the last beyond it).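

Methyl in place of phenyl on a saturated chain carbon, four bonds along the chain from a sulfur, gives a 2.6-fold higher number from compound 2 to compound 4 (0.41 log units; beyond the scatter) in this assay, the only step that can be read so far. This position is therefore not indifferent to the group it carries: phenyl goes with the lower number, by a modest margin and on a single pair. Nothing available explains this step. From the compounds shown here alone, whether an amine, a carboxylic acid or a longer chain at this place would move the number, and in which direction, remains open.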